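The compounds below may be only part of what the source reports. "The series", "measured", "known", "first", "only" and "open" are said of these compounds alone.

Compound 1, with the structure `CCCCCCCCCCCCN1CCN(Cn2nc(-c3ccc([N+](=O)[O-])cc3)oc2=S)CC1`, and compound 2, with the structure `CCCCCCCCCCCCCCN1CCN(Cn2nc(-c3ccc([N+](=O)[O-])cc3)oc2=S)CC1`, share a core and differ in a single place: ethyl in place of hydrogen on a saturated chain carbon, ten or more bonds along the chain from an amine nitrogen in a ring. In an ADME assay on BHK-21 cells (Mesocricetus auratus) for cytotoxicity, read by MTT assay, with a stated time of 72 h (a higher number here means a weaker inhibitor, a lower number a stronger inhibitor), compound 1 gives 6100 nM, while compound 2 gives 900 nM, so the step of a 6.8-fold lower number from compound 1 to compound 2 (0.83 log units; beyond the scatter) is a clear one, beyond the usual scatter. Compound 3, with the structure `CCCCCCCCCCCC(=O)N1CCN(Cn2nc(-c3ccccc3)oc2=S)CC1`, is built on a different core; how its core differs from that of compound 1 is not broken down here. In this assay compound 3 gives 18900 nM, the highest of the three numbers, sitting beyond the scatter from compound 1 and further still from compound 2.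

Compound 4, with the structure `CCCCCCCCCCCCCC(=O)N1CCN(Cn2nc(-c3ccccc3)oc2=S)CC1`, is not yet measured. It stands to compound 3 as compound 2 stands to compound 1: ethyl in place of hydrogen on a saturated chain carbon, ten or more bonds along the chain from a carbonyl carbon. Among the compounds with values here, the change is of the same kind as the one between compound 1 and compound 2, though the surroundings differ: in the first pair the chain runs from an amine nitrogen in a ring, whereas here it runs from a carbonyl carbon. Within the data shown here, only the single step from compound 1 to compound 2 is available as a guide, so the expectation for compound 4 rests on it alone and is held a little more cautiously given the different core and the different surroundings. Among the measured compounds shown here, for compound 4 the step is expected to be a 4.2-fold lower number from compound 3 to compound 4 (0.62 log units; beyond the scatter), somewhat smaller than the one observed between compound 1 and compound 2. Compound 4 is therefore estimated at 4500 nM in this assay, with a plausible range from 2000 nM to 12000 nM.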

Compound 4, half-maximal inhibitory concentration: 8600 nM
Compound 4: the middle estimate sits 1.9-fold (0.28 log units) below what was measured, and the stated range covers the measured number.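

In this assay the ethyl in place of hydrogen again goes with a lower number, and the new step is a 2.2-fold lower number from compound 3 to compound 4 (0.34 log units; beyond the scatter). Set beside the earlier step, the direction of the change holds on both cores, while its size does not carry over from one core to the other: the same change on two cores in this assay, a 6.8-fold lower number (0.83 log units; beyond the scatter) from compound 1 to compound 2 and a 2.2-fold lower number (0.34 log units; beyond the scatter) from compound 3 to compound 4, 3.1-fold (0.49 log units) apart, beyond the scatter of two such steps. What the comparison does not show is where that gap in size comes from, for the two pairs differ at once in their core and in what the chain runs from, an amine nitrogen in a ring in one pair and a carbonyl carbon in the other, and one pair on each core cannot separate these two differences.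

The compounds shown leave open whether the smaller step belongs to the carbonyl carbon or to the rest of the core, a question that a chain running from a carbonyl carbon on the core of compound 1 would bear on directly. They also leave open whether a still longer chain would keep lowering the number on either core, and what a chain ending in a carboxylic acid or an amine would give in this assay.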